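This account rests on a few compounds, and the source may have more. Where it says the series, first, only, none or still open, it means among the compounds named here.

Compound 1 `CCCCCSc1nsnc1C1=CCN(C)CC1`: > 10000 nM
Compound 2 `CN1CCC=C(c2nsnc2SCCCF)C1`: 79.7 nM

In an assay on ileum for binding affinity to muscarinic acetylcholine receptor M3 (Cavia porcellus) (on this read-out higher numbers stand for weaker inhibition and lower numbers for stronger inhibition), compound 1 gives > 10000 nM, which is a limit of the assay (the limit of > 10000 nM in this assay, at which 1 of the 2 values shown sits). Going by the values given here, compound 2 in this assay gives 79.7 nM, the only number among the two values shown. Compound 3 `CN1CCC=C(c2nsnc2SCCCCCF)C1` has not yet been measured; it differs from compound 2 by 2-fluoroethyl in place of fluoro on a saturated chain carbon, three bonds along the chain from a sulfur. Among the compounds with values here, no measured step between compounds is available, so the size of the change can only be expected. Compound 3 is expected to bind more weakly, with the step of a 19-fold higher number from compound 2 to compound 3 (1.27 log units; beyond the scatter) expected to lie beyond the scatter. Compound 3 is estimated at 1500 nM, between 300 nM and 10000 nM.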

Compound 3, inhibition constant: 160 nM
For compound 3 the middle estimate is 9.4-fold (0.97 log units) above the measured one; the whole stated range lies above it.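

In this assay, placing 2-fluoroethyl in place of fluoro on a saturated chain carbon, three bonds along the chain from a sulfur, gives a step within the usual scatter (a 2.0-fold higher number from compound 2 to compound 3 (0.30 log units; within the scatter)), so this position accepts this change without a measurable loss of binding. Going by these compounds alone, this is the first step between compounds that differ in one place. Nothing measured here gives a reason for this outcome.

On these data alone, it remains open whether an amine or a hydroxyl group in place of fluoro at this position, or a longer chain, would keep binding in this assay at this level.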